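Compound 3 to compound 4: fluoro in place of bromo

A few compounds are considered here, and "the series" means these few. Any claim that something is new, unique, unknown or untested is made for them only; others in the source may bear on it.

For the measured compounds named here, in a functional assay on MCF7 cells (Homo sapiens) for antiproliferative activity, read by MTT assay (a higher number here means a weaker inhibitor, a lower number a stronger inhibitor), compound 3 (`O=[N+]([O-])c1ccc(Nc2nccc(-c3ccc(Br)cc3)n2)cc1`) gives 681000 nM, the highest of the three numbers so far. Compound 2 (`Cc1cccc(Nc2nccc(-c3ccc(Br)cc3)n2)c1`), which also carries the 4-bromophenyl group, reads lower at 210000 nM. Compound 1 (`COc1ccc(-c2ccnc(Nc3ccc([N+](=O)[O-])cc3)n2)cc1`) reads far lower at 770 nM.

Compound 4 (`O=[N+]([O-])c1ccc(Nc2nccc(-c3ccc(F)cc3)n2)cc1`) changes compound 3 in one place: fluoro in place of bromo on an aromatic carbon. This is fluoro in place of bromo on an aromatic carbon, para to a large group, so 4-bromophenyl becomes 4-fluorophenyl.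

Going by the values given here, only one measured step touches this position: an 880-fold higher number from compound 1 to compound 3 (2.95 log units; beyond the scatter), with bromo in place of methoxy. That step is large and beyond the scatter, so the position can move the number strongly. Among the compounds with values here, it does not size the present change, however, as no fluoro compound has been measured and the group entering here is not methoxy. Some recovery from the bromo level is expected, though only part of the gap to compound 1, and the uncertainty is wide. The expected change is a 6.8-fold lower number from compound 3 to compound 4 (0.83 log units; beyond the scatter), towards a lower number. For compound 4 the estimated value is 100000 nM, with an expected range of 8000 nM to 800000 nM.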

Compound 4, half-maximal inhibitory concentration: 400 nM
The estimate for compound 4 lay 250-fold (2.40 log units) above the measured number; the measured number lies below the stated range.
By their numbers in this assay, from the lowest: compounds 4 and 1 (each within the scatter of the next); then compound 2; then compound 3.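

In this assay, for the compounds shown here, the position had so far been seen only through bromo in place of methoxy, and swapping one halogen for another on the same aromatic carbon proves just as consequential: a 1700-fold lower number from compound 3 to compound 4 (3.23 log units; beyond the scatter). Fluoro and methoxy are not separated at this position, a 1.9-fold lower number from compound 1 to compound 4 (0.28 log units; within the scatter), so among these three groups on the shared core, bromo alone stands apart, and the position does not simply reward any replacement of methoxy. Nothing available explains what sets bromo apart from fluoro and methoxy here.

From the compounds shown here alone, whether the sharp loss belongs to bromo alone or extends to other groups at this position, such as chloro, an amine or a carboxylic acid, remains open. Also open, going by these compounds, is whether fluoro brings a similar drop when the nitro-bearing ring is replaced by the methyl-bearing ring of compound 2, which carries the 4-bromophenyl group and reads 210000 nM in this assay.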